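The compounds below may be only part of what the source reports. "The series", "measured", "known", "first", "only" and "open" are said of these compounds alone.

Compound 1 `O=C(O)C12CC(CN3CCC[C@H](O[C@H](CO)c4cc(Cl)cc(Cl)c4)[C@@H]3c3ccccc3)(C1)C2` — in an assay on isolated protein for activation of cGMP-dependent protein kinase 1 (Homo sapiens), read by ADP-Glo, with stated times of 30 min and 2 h (a lower number here means that less compound is needed, a higher number that more compound is needed for the effect), compound 1 gives > 200000 nM, which is a limit of the assay and not a number.
Compound 2 `OC[C@@H](O[C@H]1CCCN(Cc2nc3ccccc3[nH]2)[C@H]1c1ccccc1)c1cc(Cl)cc(Cl)c1` — in this assay compound 2 gives > 200000 nM, likewise a limit of the assay.

Among the measured compounds shown here, compound 2 therefore stands nowhere on a scale of numbers: it is known only as a limit, and the one further value shown, for compound 1, is a limit too, as the limit of > 200000 nM in this assay, at which 2 of the 2 values shown sit, records. For the measured compounds named here, the single measured step, a step that the two limits leave unreadable from compound 1 to compound 2, exchanges the bicyclic carboxylic acid for the benzimidazole on the saturated chain carbon bound to the ring amine nitrogen, and its size cannot be read.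

Compound 3 `O=C(O)c1ccc(CN2CCC[C@H](O[C@H](CO)c3cc(Cl)cc(Cl)c3)[C@@H]2c2ccccc2)c([N+](=O)[O-])c1` differs from compound 2 by 4-carboxy-2-nitrophenyl in place of 1H-benzimidazol-2-yl on a saturated chain carbon bound to an amine nitrogen in a ring. Going by the values given here, no measured step bears directly on this exchange, and the one step that exists is unreadable, so nothing in the data points to a direction or a size. Given that both measured compounds sit at the limit, compound 3 is expected to remain there as well, with an estimated 250000 nM and a range from 60000 nM to 1000000 nM. The expected step that the limit leaves unreadable from compound 2 to compound 3 is accordingly estimated as none that could be read against the limit.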

Compound 3, half-maximal effective concentration: 13000 nM
Compound 3: the middle estimate sits 19-fold (1.28 log units) above what was measured; measured number below the stated range.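

At the saturated chain carbon bound to the ring amine nitrogen, the choice of group now makes a readable difference in this assay: 4-carboxy-2-nitrophenyl in place of 1H-benzimidazol-2-yl gives an at least 15-fold lower number from compound 2 to compound 3 (1.18 log units; beyond the scatter). A carboxylic acid is not enough by itself, as the bicyclic group with its two four-membered rings carries one too, yet exchanging that group for 4-carboxy-2-nitrophenyl gives an at least 15-fold lower number from compound 1 to compound 3 (1.18 log units; beyond the scatter). Both steps start from a limit of the assay, so their full sizes cannot be read, and compound 3 is the only compound here with a number rather than a limit: the limit of > 200000 nM in this assay, at which 2 of the 3 values shown sit.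

The nitro group and the carboxylic acid enter together, so the compounds shown do not tell how much of the change belongs to either of them, or whether the phenyl ring needs both. They also leave open whether an amide or a tetrazole could stand in for the carboxylic acid, and whether a longer chain between the ring amine nitrogen and the phenyl ring would keep the number of compound 3.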